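Swapping an amide-linked amino acid for a pyrrolidine ring

A few compounds are considered here, and "the series" means these few. Any claim that something is new, unique, unknown or untested is made for them only; others in the source may bear on it.

Of the compounds shown here, two that share one core have been measured in a functional assay on CCRF-CEM cells (Homo sapiens) for antiproliferative activity; on this read-out higher numbers stand for lower toxicity in this test and lower numbers for higher toxicity in this test. Compound 1 `Cc1cn(C2OC(CO[Si](C)(C)C(C)(C)C)C3(OS(=O)(=O)C=C3N)C2O[Si](C)(C)C(C)(C)C)c(=O)n(CCCNC(=O)[C@@H]2CCCN2C(=O)[C@H](C)N)c1=O` carries a proline-type ring capped with an aminoethyl carbonyl group; in this assay compound 1 gives 19000 nM. Compound 2 `Cc1cn(C2OC(CO[Si](C)(C)C(C)(C)C)C3(OS(=O)(=O)C=C3N)C2O[Si](C)(C)C(C)(C)C)c(=O)n(CCCNC(=O)[C@H](C)NC(=O)[C@@H](N)C(C)C)c1=O` has instead an open-chain alanine-like unit capped with a valine-like group; in this assay compound 2 gives 11000 nM. Within the data shown here, the only step measured so far, a 1.7-fold lower number from compound 1 to compound 2 (0.24 log units; within the scatter), is too small to count as a real difference, so compound 2 stands at the same level as compound 1 rather than apart from it.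

Compound 3 `Cc1cn(C2OC(CO[Si](C)(C)C(C)(C)C)C3(OS(=O)(=O)C=C3N)C2O[Si](C)(C)C(C)(C)C)c(=O)n(CCCNC(=O)[C@H]2CCCN2C(=O)[C@@H](N)C(C)C)c1=O` is the unmeasured partner: 1-((1-amino-2-methylpropyl)carbonyl)pyrrolidin-2-yl in place of 1-(((1-amino-2-methylpropyl)carbonyl)amino)ethyl on a carbonyl carbon. This change returns the pyrrolidine ring seen in compound 1 while keeping the valine-like cap of compound 2. Among the measured compounds shown here, the one measured step altered both the ring and the cap together and stayed within the scatter, so it offers no sign that either part moves the number much. The expectation for compound 3 is therefore a step of a 1.3-fold higher number from compound 2 to compound 3 (0.10 log units; within the scatter), within the scatter. Compound 3 is estimated at 14000 nM, with a range from 6000 nM to 35000 nM.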

Compound 3, half-maximal cytotoxic concentration: 11000 nM
For compound 3 the middle estimate is 1.3-fold (0.10 log units) above the measured one, and the stated range covers the measured number.
By their numbers in this assay, from the lowest: compounds 2, 3 and 1 (each within the scatter of the next).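

Compound 3 splits the earlier step, where ring and cap changed together, into two single changes. In this assay, placing 1-((1-amino-2-methylpropyl)carbonyl)pyrrolidin-2-yl where the open-chain 1-(((1-amino-2-methylpropyl)carbonyl)amino)ethyl stood tests the ring alone (no change at the digits printed from compound 2 to compound 3 (within the scatter)), and placing it where 1-((1-aminoethyl)carbonyl)pyrrolidin-2-yl stood tests the cap on the ring alone (a 1.7-fold lower number from compound 1 to compound 3 (0.24 log units; within the scatter)), so on this carbonyl carbon neither single change stands out from the scatter, and all three compounds sit at one level. Nothing measured alongside these numbers offers an explanation for how closely they agree.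

As far as these compounds go, all three groups end in a free amine and carry small carbon side chains, so it remains open whether a cap ending in a carboxylic acid, or one bearing a phenyl ring, would separate from this level. From the compounds shown here alone, it is also open whether a longer chain in the linking unit would shift the number beyond the scatter.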